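Tert-butyl in Place of Methoxy: Expected Cytotoxicity of Compound 4

The source may report more compounds than this note shows. Statements on the series, on what has been measured and on what is new or still open speak of the compounds shown alone.

Compound 1, `COc1ccc(Oc2ccc3c(NCCCNCc4cc(F)ccc4OC)ccnc3c2)cc1`: 7000 nM
Compound 2, `COc1ccc(Oc2ccc3c(NCCCNCc4cccc(OC)c4O)ccnc3c2)cc1`: 5500 nM
Compound 3, `c1coc(CNCCCNc2ccnc3cc(CC4CCCCC4)ccc23)c1`: 1700 nM

In an ADME assay on HepG2 cells (Homo sapiens) for cytotoxicity, read by luminescence, CellTiter-Glo and ATP content, with a stated time of 72 h (a lower number here means that less compound is needed, a higher number that more compound is needed for the effect), compound 1 gives 7000 nM, the highest of the three numbers. The nearest number belongs to a step within the scatter: a 1.3-fold lower number from compound 1 to compound 2 (0.10 log units; within the scatter). Within the data shown here, compound 3 gives 1700 nM, a number beyond the scatter from that of compound 1, but compound 3 differs in more than one place, so no single step links the two.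

Compound 4, `COc1ccc(F)cc1CNCCCNc1ccnc2cc(Oc3ccc(C(C)(C)C)cc3)ccc12`, differs from compound 1 in one place: tert-butyl in place of methoxy on an aromatic carbon. Among the measured compounds shown here, no measured step touches this position; the one step on record changes the group on the chain carbon instead and stays within the scatter. Compound 4 is therefore expected to show no step beyond the scatter, a 1.3-fold lower number from compound 1 to compound 4 (0.10 log units; within the scatter). The estimate for compound 4 is 5500 nM, with a range from 2500 nM to 14000 nM.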

Compound 4, half-maximal effective concentration: 7200 nM
For compound 4 the middle estimate is 1.3-fold (0.12 log units) below the measured one; low and high end bracket the measured number.
By their numbers in this assay, from the lowest: compound 3; then compounds 2, 1 and 4 (each within the scatter of the next).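

In this assay, among these compounds, the one step read at this aromatic carbon is a 1.0-fold higher number from compound 1 to compound 4 (0.01 log units; within the scatter) and replaces methoxy, with its hydrogen-bond acceptor, by tert-butyl, which has none. The earlier step changed only the group on the chain carbon, whereas this one shows that 4-methoxyphenoxy can give way to the larger 4-(tert-butyl)phenoxy without a step beyond the scatter. As far as these compounds go, whether an amine or a carboxylic acid on this aromatic carbon would also stay within the scatter of compound 1 remains open, as does whether the same exchange would do so on compound 2. Nothing at hand accounts for this result.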